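The source may report more compounds than this note shows. Statements on the series, on what has been measured and on what is new or still open speak of the compounds shown alone.

Measured compounds:
- compound 1 `Nc1cc(N)c2nc(-c3ccccc3)c(Oc3ccc(F)cc3)nc2c1` — 15500 nM
- compound 2 `CCOC(=O)[C@H](CCC(=O)O)NC(=O)c1ccc(CNc2nc3cc(N)cc(N)c3nc2-c2ccccc2)cc1` — < 100000 nM, a limit of the assay and not a number
- compound 3 `COc1ccc(CNc2nc3cc(N)cc(N)c3nc2-c2ccccc2)cc1` — 15100 nM

These three share a core and differ in the group attached to it. In a functional assay on 786-0 cells (Homo sapiens) for inhibition, read by sulforhodamine B assay, with a stated time of 48 h (a lower number here means a stronger inhibitor of growth, a higher number a weaker inhibitor of growth), compound 1 gives 15500 nM, the highest of the two numbers shown. Compound 3, the nearest, sits within the usual scatter of compound 1, so no order between the two can be read. For compound 2 only a limit is reported, (the limit of < 100000 nM in this assay, at which 1 of the 3 values shown sits), so it gives no number to compare.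

Compound 4 `COc1ccc(Sc2nc3cc(N)cc(N)c3nc2-c2ccccc2)cc1` has not yet been measured. Relative to compound 1 its change is (4-methoxyphenyl)sulfanyl in place of 4-fluorophenoxy on an aromatic carbon. Among the measured compounds shown here, no measured pair shows a step of this kind, so there is no direct guide to its size. Given that compound 1 and compound 3 carry quite different groups at the same place and still land together, the expected step of a 1.0-fold lower number from compound 1 to compound 4 (0.01 log units; within the scatter) is none beyond the scatter. Compound 4 is estimated at 15000 nM, with a likely range from 4000 nM to 60000 nM.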

Compound 4, concentration for 50% growth inhibition: 13200 nM
Beside the measured number, compound 4's estimate is 1.1-fold (0.06 log units) above it; the range from low to high includes it.
By their numbers in this assay, from the lowest: compounds 4, 3 and 1 (each within the scatter of the next).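

Changing 4-fluorophenoxy to (4-methoxyphenyl)sulfanyl on the aromatic carbon next to the ring nitrogen gives a 1.2-fold lower number from compound 1 to compound 4 (0.07 log units; within the scatter) in this assay, the first single step measured at this position. The atom joining the outer ring to the core goes from oxygen to sulfur, and the group on that ring goes from fluorine to methoxy, yet together these two differences leave the number within the scatter. No measurement shown here gives a reason why these two groups read alike.

On these data alone, the step changes the joining atom and the group on the outer ring together, so the effect of each alone remains unknown, and either effect could be hidden by the other. As far as these compounds go, it also remains open how a group without an outer ring, such as a hydroxyl or a short alkyl chain, would read at this position.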